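Adding a Methyl Group to the Phenyl of Compound 3

The source may hold more compounds than are shown below. What is called first, only, known or untested is meant among the compounds shown, and "the series" means these compounds.

Measured compounds:
compound 1 `CCCCCCOc1ccc(-n2cnnc2C)cc1` gives 22.8 mg/kg in a functional assay on the whole organism (strain C57B/6) with Mus musculus as the target, in the maximal electroshock model; on this read-out higher numbers stand for an effect only at larger amounts of compound and lower numbers for an effect already at smaller amounts;
compound 2 `CCCCCCOc1ccc(-n2cnnc2CC)cc1` gives 13.2 mg/kg in this assay;
compound 3 `CCCCCCOc1ccc(-n2cnnc2-c2ccccc2)cc1` gives 19 mg/kg in this assay.

Compound 3 sits among three numbers that hardly differ: its step from compound 1 is a 1.2-fold lower number from compound 1 to compound 3 (0.08 log units; within the scatter) and its step from compound 2 is a 1.4-fold higher number from compound 2 to compound 3 (0.16 log units; within the scatter), so no order among the three can be read from this assay.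

Compound 4 `CCCCCCOc1ccc(-n2cnnc2-c2ccc(C)cc2)cc1` differs from compound 3 by methyl in place of hydrogen on an aromatic carbon. Going by the values given here, the only measured step that adds a methyl group is a 1.7-fold lower number from compound 1 to compound 2 (0.24 log units; within the scatter), and there the methyl enters on a chain carbon rather than on an aromatic carbon, so it bears on the new step only loosely. Every change so far, a 1.7-fold lower number from compound 1 to compound 2 (0.24 log units; within the scatter), a 1.2-fold lower number from compound 1 to compound 3 (0.08 log units; within the scatter) and a 1.4-fold higher number from compound 2 to compound 3 (0.16 log units; within the scatter), has stayed within the scatter. The step of a 1.1-fold lower number from compound 3 to compound 4 (0.05 log units; within the scatter) is therefore expected to be no larger than the scatter, in either direction. Compound 4 is expected to give 17 mg/kg, with a range from 8 mg/kg to 35 mg/kg.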

Compound 4, dose for half-maximal effect: 11.4 mg/kg
Estimate against measurement, compound 4: 1.5-fold (0.17 log units) above; measured number inside the range.
By their numbers in this assay, from the lowest: compounds 4, 2, 3 and 1 (each within the scatter of the next).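

In this assay, going by these compounds alone, the change reaches the phenyl ring itself for the first time, and a methyl on this aromatic carbon gives a 1.7-fold lower number from compound 3 to compound 4 (0.22 log units; within the scatter), so this place accepts the methyl with no change that can be told from the scatter. The larger 4-methylphenyl group also stays level with the smaller groups on the shared core, with a 1.2-fold lower number from compound 2 to compound 4 (0.06 log units; within the scatter) and a 2.0-fold lower number from compound 1 to compound 4 (0.30 log units; within the scatter), so methyl, ethyl, phenyl and 4-methylphenyl give no readable order here. No measurement is available that would explain these numbers.

As far as these compounds go, whether a methoxy group, a chlorine atom or an amine in place of this methyl would give a step beyond the scatter stays open. From the compounds shown here alone, the effect of the same methyl at other places on that ring also stays open.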